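Flavanone Side Chains Stay at the Cytotoxicity Limit

This account rests on a few compounds, and the source may have more. Where it says the series, first, only, none or still open, it means among the compounds named here.

Three measured compounds share one core and differ only in the chain attached to it. Compound 1 `COC(C)(C)/C=C/C/C(C)=C/Cc1c(O)ccc2c1O[C@H](c1ccc(O)cc1)CC2=O` carries a 3-methoxy-3-methylbut-1-en-1-yl group; in a functional assay on HepG2 cells (Homo sapiens) for cytotoxicity, read by MTT assay (a higher number here means a weaker inhibitor, a lower number a stronger inhibitor), compound 1 returns only a limit of the assay, > 10000 nM. Compound 2 `COC(C=C(C)C)C/C(C)=C/Cc1c(O)ccc2c1O[C@H](c1ccc(O)cc1)CC2=O` has 1-methoxy-3-methylbut-2-en-1-yl in place of that group on a saturated chain carbon bound to a double-bonded chain carbon, and in this assay compound 2 likewise returns a limit, > 10000 nM. The step between them, a step that the two limits leave unreadable from compound 1 to compound 2, cannot be read as a number. Compound 3 `CC1=CCC(O)C(C)(C)C1Cc1c(O)ccc2c1O[C@H](c1ccc(O)cc1)CC2=O` carries a 5-hydroxy-2,6,6-trimethylcyclohex-2-en-1-yl group; in this assay compound 3 also gives a limit, > 10000 nM. Compound 3 therefore stands where every measured value stands, at the limit of > 10000 nM in this assay, at which 3 of the 3 values shown sit.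

Compound 4 `CC(C)=CCC/C(C)=C/Cc1c(O)ccc2c1O[C@H](c1ccc(O)cc1)CC2=O` is the unmeasured member. The change is 2,6-dimethylhepta-1,5-dien-1-yl in place of 5-hydroxy-2,6,6-trimethylcyclohex-2-en-1-yl on a saturated chain carbon bound to an aromatic carbon. Going by the values given here, no measured step touches this part of the molecule, and the single measured step is unreadable, so nothing points away from the limit. The expected step is a step that the limit leaves unreadable from compound 3 to compound 4, none beyond the scatter. Compound 4 is therefore expected to give about 20000 nM, within 8000 nM to 60000 nM, most likely as a limit once more.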

Compound 4, half-maximal inhibitory concentration: > 10000 nM
Compound 4: only a limit was reported (the forecaster's own chance of this, stated with the estimate: 85%); the middle value is on the limit's open side.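

The steps from compound 1, compound 2 and compound 3 to compound 4 cannot be read as sizes, since all four compounds stand at one place: the limit of > 10000 nM in this assay, at which 4 of the 4 values shown sit.

On these data alone, how far apart these four compounds truly lie, and whether any chain on the shared core gives a measurable value, stays open.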